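The source may report more compounds than this note shows. Statements on the series, on what has been measured and on what is new or still open speak of the compounds shown alone.

Measured so far:
Compound 1 `Cc1nn([C@H](C)c2ccc(Cl)cc2Cl)c2nc(N3CC[C@H](N4CCCC4)[C@H](C)C3)cnc12` gives 69 nM.
Compound 2 `Cc1nn([C@H](C)c2ccc(Cl)cc2Cl)c2nc(N3CC[C@H](N4CCC[C@H]4CCS(C)(=O)=O)[C@H](C)C3)cnc12` gives 104 nM.
Compound 3 `Cc1nn([C@H](C)c2ccc(Cl)cc2Cl)c2nc(N3CC[C@H](N4CCCCC4)[C@H](C)C3)cnc12` gives 42 nM.

All three numbers come from a functional assay on cells for antagonist activity at C-C chemokine receptor type 4 (Homo sapiens), read by fluorescence and calcium flux, with stated times of 2.5 s and 45 s; on this read-out higher numbers stand for weaker inhibition and lower numbers for stronger inhibition. Compound 3 holds the lowest number of the three; the two steps ending there read a 1.6-fold lower number from compound 1 to compound 3 (0.22 log units; within the scatter) and a 2.5-fold lower number from compound 2 to compound 3 (0.39 log units; beyond the scatter), so only the second is separated from it beyond the scatter.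

Compound 4 `Cc1nn([C@H](C)c2ccc(Cl)cc2Cl)c2nc(N3CC[C@H](N4CCC[C@H]4CCC(N)=O)[C@H](C)C3)cnc12` differs from compound 3 in one place: 2-(2-carbamoylethyl)pyrrolidin-1-yl in place of piperidin-1-yl on a saturated ring carbon. Going by the values given here, two measured steps bear on this. Swapping the six-membered for the five-membered ring alone gave a 1.6-fold lower number from compound 1 to compound 3 (0.22 log units; within the scatter), within the scatter. Putting a two-carbon chain with a terminal polar group on that five-membered ring gave a 1.5-fold higher number from compound 1 to compound 2 (0.18 log units; within the scatter), also within the scatter, while the combined change read a 2.5-fold lower number from compound 2 to compound 3 (0.39 log units; beyond the scatter). The closest measured analogue of compound 4 is thus compound 2, and a modest rise in number from compound 3 is expected, roughly undoing the combined step.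

The expected step is a 2.1-fold higher number from compound 3 to compound 4 (0.33 log units; beyond the scatter). Compound 4 is therefore estimated at 90 nM in this assay, with a range from 35 nM to 230 nM.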

Compound 4, half-maximal inhibitory concentration: 37 nM
Compound 4: middle estimate off by 2.4-fold (0.39 log units), on the high side; measured number inside the range.
By their numbers in this assay, from the lowest: compounds 4, 3, 1 and 2 (each within the scatter of the next, the first and the last beyond it).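

In this assay, 2-(2-carbamoylethyl)pyrrolidin-1-yl in place of piperidin-1-yl gives a 1.1-fold lower number from compound 3 to compound 4 (0.06 log units; within the scatter) and so is not separated from the smaller group, despite its added hydrogen-bond donor. Read from the unsubstituted pyrrolidine, 2-carbamoylethyl in place of hydrogen gives a 1.9-fold lower number from compound 1 to compound 4 (0.27 log units; within the scatter) and likewise leaves the number within the scatter. Going by these compounds alone, the end of the chain is where this series first separates with ring and chain length held constant: carbamoyl in place of methylsulfonyl gives a 2.8-fold lower number from compound 2 to compound 4 (0.45 log units; beyond the scatter) and is the only one of these changes to lie beyond the scatter.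

The compounds shown offer no measurement that explains this difference between the two chain ends. Open too, on these data alone, is where a carboxylic acid or primary amine at the chain end, or a longer chain carrying the carbamoyl group, would fall.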